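The source may hold more compounds than are shown below. What is called first, only, known or untested is meant among the compounds shown, and "the series" means these compounds.

Measured compounds:

- compound 1, `Nc1cc(Cc2ccn(-c3ccc(F)cc3)n2)c2nn[nH]c2n1`: 53 nM
- compound 2, `Nc1cc(Cc2ccn(Cc3ccc4ccccc4c3)n2)c2nn[nH]c2n1`: 52 nM
- compound 3, `Nc1cc(C2CCNC3CCC(CC3)COc3cccc(c3)Cn3cc2cn3)c2nn[nH]c2n1`: 31 nM

All three share the same core and were tested in an assay on isolated protein for inhibition of Myeloperoxidase (Homo sapiens), with a stated time of 10 min; a higher number here means a weaker inhibitor, a lower number a stronger inhibitor. In this assay compound 1 gives 53 nM, compound 2 gives 52 nM and compound 3 gives 31 nM. Compound 1 sits at the upper end of these three numbers, but its gap to compound 2 and its gap to compound 3 both fall within the usual scatter of repeated measurements, so the three compounds cannot be told apart on the numbers shown.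

The new compound is compound 4, `Nc1cc(Cc2ccn(-c3ccccc3)n2)c2nn[nH]c2n1`. It differs from compound 1 in a single place: hydrogen in place of fluoro on an aromatic carbon. Put another way, the 4-fluorophenyl of compound 1 becomes a plain phenyl; the fluoro leaves from the aromatic carbon and a hydrogen enters in its stead.

Among the compounds with values here, no measured pair in this set shows what removing a fluoro does here, so no step size can be read off from the data. With such a small change in a part of the molecule remote from the core, the expected step is a 1.2-fold higher number from compound 1 to compound 4 (0.09 log units; within the scatter), which is to say no change beyond the scatter in either direction. Compound 4 is therefore expected to give about 65 nM in this assay, with a likely range from 25 nM to 170 nM.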

Compound 4, half-maximal inhibitory concentration: 55 nM
Compound 4: the middle estimate sits 1.2-fold (0.07 log units) above what was measured; the measured number falls inside the stated range.
By their numbers in this assay, from the lowest: compounds 3, 2, 1 and 4 (each within the scatter of the next).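

Removing the fluoro from the 4-fluorophenyl gives, in this assay, a 1.0-fold higher number from compound 1 to compound 4 (0.02 log units; within the scatter). Within the data shown here, this is the first direct reading at this position, which none of the earlier compounds could give, since no two of them differed in only one place. On the aromatic carbon para to a large group, the fluorine atom is not needed to hold the number in this assay, and the plain phenyl cannot be told apart from the 4-fluorophenyl, although no measurement here bears on the reason for this result.

Going by these compounds, only fluoro and hydrogen can be compared at this position, so it remains open whether a larger group there, such as a methoxy, a carboxylic acid or an amine on a longer chain, would move the number beyond the scatter. Among these compounds, also open is what replacing the whole phenyl with a small group such as a methyl or a cyclohexyl would do, as compound 2 and compound 3 each differ from compound 4 in more than one place and give no clean step.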